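The source may hold more compounds than are shown below. What is called first, only, known or untested is meant among the compounds shown, and "the series" means these compounds.

Of the compounds shown here, three from this series have been measured in an assay on HEK293 cells for displacement of a labelled ligand from 5-hydroxytryptamine receptor 7 (Homo sapiens); on this read-out lower numbers stand for stronger inhibition and higher numbers for weaker inhibition. Compound 1, `O=C1c2ccccc2S(=O)(=O)N1CCCCCN1CCN(c2ccc(Cl)cc2)CC1`, gives 191 nM. Compound 2, `COc1ccccc1N1CCN(CCCCCN2C(=O)c3ccccc3S2(=O)=O)CC1`, gives 125 nM. Compound 3, `COc1ccccc1N1CCN(CCCCCCN2C(=O)c3ccccc3S2(=O)=O)CC1`, gives 105 nM. All three numbers fall within the usual scatter of one another, so no order among them can be read from these values.

Compound 3 and compound 2 share the same ring systems but differ in the part that joins them; the difference between the two cores is not broken down here.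

Compound 1 and compound 2 differ in one place:

4-chlorophenyl in place of 2-methoxyphenyl on an amine nitrogen in a ring

This change produced a 1.5-fold higher number from compound 2 to compound 1 (0.18 log units; within the scatter).

Compound 4, `O=C1c2ccccc2S(=O)(=O)N1CCCCCCN1CCN(c2ccc(Cl)cc2)CC1`, has not yet been measured in this assay. It differs from compound 3 in one place:

4-chlorophenyl in place of 2-methoxyphenyl on an amine nitrogen in a ring

This is the same change, at the same kind of position, as the one that takes compound 2 to compound 1, and it occurs twice among the compounds shown.

For the measured compounds named here, for that reason the step from compound 3 to compound 4 is expected to be about a 1.5-fold higher number from compound 3 to compound 4 (0.18 log units; within the scatter), a size that rests on the single earlier instance of the change, namely a 1.5-fold higher number from compound 2 to compound 1 (0.18 log units; within the scatter), which itself lay within the scatter. Going by the values given here, since only one prior example is available, the expectation is held loosely.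

Compound 4 is therefore estimated to give 160 nM in this assay, with a plausible range from 80 nM to 320 nM.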

Compound 4, inhibition constant: 487 nM
For compound 4 the middle estimate is 3.0-fold (0.48 log units) below the measured one; measured number above the stated range.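

In this assay, 4-chlorophenyl in place of 2-methoxyphenyl on the amine nitrogen in the ring now gives a 4.6-fold higher number from compound 3 to compound 4 (0.67 log units; beyond the scatter), a step that lies beyond the scatter, whereas the same change on the other core did not. The size of this change therefore did not carry over unaltered from one core to the other, so a step read on one core was not a safe measure of the step on the other: the same change on two cores in this assay, a 1.5-fold higher number (0.18 log units; within the scatter) from compound 2 to compound 1 and a 4.6-fold higher number (0.67 log units; beyond the scatter) from compound 3 to compound 4, 3.0-fold (0.48 log units) apart, beyond the scatter of two such steps. With only two instances, this shows that the step can depend on the core, but it gives no general rule for the series, and it does not show which feature of the part joining the ring systems accounts for the gap or whether the same gap would appear on any other core.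

The compounds shown leave open how the step would behave on a longer chain joining the ring systems, and whether it would keep growing, level off or shrink. They also leave open how a plain phenyl on the same ring nitrogen would stand, which would help to separate what the departure of the 2-methoxyphenyl contributes from what the arrival of the 4-chlorophenyl contributes.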